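Working notes on three measured compounds and one open

The compounds below may be only part of what the source reports. "The series", "measured", "known", "first", "only" and "open" are said of these compounds alone.

compound 1 `CC(O)(C[S+]([O-])c1ccc(C(F)(F)F)cn1)C(=O)Nc1ccc(C#N)c(C(F)(F)F)c1`: > 100000 nM; > 100000 nM (2 entries)
compound 2 `CC(O)(C[S+]([O-])c1ccccn1)C(=O)Nc1ccc([N+](=O)[O-])cc1C(F)(F)F`: 100000 nM
compound 3 `CC(O)(C[S+]([O-])c1ccccn1)C(=O)Nc1ccc(C#N)c(C(F)(F)F)c1`: > 100000 nM

Among the compounds with values here, in a functional assay on VCaP cells (Homo sapiens) for antiproliferative activity (a lower number here means a stronger inhibitor, a higher number a weaker inhibitor), compound 2 gives 100000 nM, which is the only plain number among the three results. For compound 1 the two entries are both limits of the assay, > 100000 nM; > 100000 nM (2 entries). For compound 3 the entry is likewise a limit, > 100000 nM. Compound 3 thus sits at the limit of > 100000 nM in this assay, at which 1 of the 3 values shown sits. Within the data shown here, since no value lies clearly apart from another, no compound can be called weaker or stronger than the rest, and no step between measured pairs is available.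

Compound 4 `CC(O)(C[S+]([O-])c1ccc(C(F)(F)F)cc1)C(=O)Nc1ccc([N+](=O)[O-])cc1C(F)(F)F` differs from compound 2 in one place, (4-(trifluoromethyl)phenyl in place of pyridin-2-yl on a sulfur). Among the measured compounds shown here, the measured compounds offer no step of this kind to lean on, and compound 2 already gives a value at the edge of the working range. The expectation is therefore no step beyond the usual scatter in this assay, in either direction, from compound 2 to compound 4. Compound 4 is estimated at 100000 nM, with a range from 30000 nM to 300000 nM, and the step of no change at the digits printed from compound 2 to compound 4 (within the scatter) is expected to be negligible; a fair chance remains that the assay reports only a limit again.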

Compound 4, half-maximal inhibitory concentration: 24200 nM
Beside the measured number, compound 4's estimate is 4.1-fold (0.62 log units) above it, outside the stated range (below it).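

In this assay, the sulfur substituent is now shown to be a place where a change can move the result, with 4-(trifluoromethyl)phenyl in place of pyridin-2-yl giving a 4.1-fold lower number from compound 2 to compound 4 (0.62 log units; beyond the scatter) and thus the first value in the series clearly away from the top of the range. The change swaps a ring with one nitrogen and one hydrogen-bond acceptor for a carbon-only ring carrying three fluorines, but the data do not show which of these differences matters. The step also starts from a compound 2 value that equals the number at which the assay's limit stands, so its true size is uncertain: the limit of > 100000 nM in this assay, at which 1 of the 4 values shown sits.

Steps involving the limit values of compound 1 and compound 3 cannot be read, so it remains open whether the same replacement would help with the nitrile-bearing anilide of compound 3. Also open, on these data alone, is whether an unsubstituted phenyl, or a phenyl carrying a carboxylic acid or an amine in place of the trifluoromethyl, would keep or extend this gain.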